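Swapping Trifluoromethyl for Bromo on the Phenyl Ring

The source may hold more compounds than are shown below. What is called first, only, known or untested is meant among the compounds shown, and "the series" means these compounds.

Of the compounds shown here, three that share one core have been tested in a functional assay on HEK293 cells for antagonist activity at transient receptor potential cation channel subfamily V member 1 (Rattus norvegicus); on this read-out lower numbers stand for stronger inhibition and higher numbers for weaker inhibition. Compound 1 `CC(C)(C)c1ccc(NC(=O)N2CCN(c3ncccc3C(F)(F)F)CC2)cc1` gives 57.7 nM. Compound 2 `CC(C)c1ccc(NC(=O)N2CCN(c3ncccc3Cl)CC2)cc1` gives 17.3 nM in this assay. Compound 3 `O=C(Nc1ccc(C(F)(F)F)cc1)N1CCN(c2ncccc2Cl)CC1` gives 81.4 nM in this assay, the highest of the three numbers; its gap to compound 1 lies within the usual scatter, whereas the step of a 4.7-fold higher number from compound 2 to compound 3 (0.67 log units; beyond the scatter) lies beyond it.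

Compound 4 `O=C(Nc1ccc(Br)cc1)N1CCN(c2ncccc2Cl)CC1` has not yet been measured. It differs from compound 3 in one place only: bromo in place of trifluoromethyl on an aromatic carbon.

Going by the values given here, only one measured step concerns a change at this same place, namely a 4.7-fold higher number from compound 2 to compound 3 (0.67 log units; beyond the scatter), and it shows that exchanging the group on that aromatic carbon can move the number by a modest amount beyond the scatter. Among the compounds with values here, no measured compound carries bromo, so neither the direction nor the size of the coming step is fixed by the numbers at hand, and the measured step gives only a rough scale. A step of about the same modest size, leaning toward a lower number, is therefore expected for compound 4, a 1.8-fold lower number from compound 3 to compound 4 (0.26 log units; within the scatter). Compound 4 is estimated to give 45 nM, with a likely range from 14 nM to 150 nM.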

Compound 4, half-maximal inhibitory concentration: 1010 nM
For compound 4 the middle estimate is 22-fold (1.35 log units) below the measured one; the measured number lies above the stated range.
By their numbers in this assay, from the lowest: compound 2; then compounds 1 and 3 (each within the scatter of the next); then compound 4.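

Going by these compounds alone, the group on this aromatic carbon matters far more than the earlier compounds suggested: in this assay, replacing trifluoromethyl with a single bromine gives a 12-fold higher number from compound 3 to compound 4 (1.09 log units; beyond the scatter) and so goes well past the earlier 4.7-fold higher number from compound 2 to compound 3 (0.67 log units; beyond the scatter) in size. Measured against isopropyl, the same position gives a 58-fold higher number from compound 2 to compound 4 (1.77 log units; beyond the scatter) as its largest shift, so with the rest of the molecule unchanged the numbers rise from isopropyl through trifluoromethyl to bromo, and each of these steps lies beyond the scatter. Nothing available here explains why bromo gives so much weaker inhibition than the other two groups.

As far as these compounds go, these three groups give only a few points at this position, so it remains open where others such as methoxy, a nitrile, an amine or a longer alkyl chain would fall, and whether any would give a lower number than isopropyl. From the compounds shown here alone, it is also open whether bromo would have as large an effect on a compound that carries trifluoromethyl rather than chloro on the other aromatic ring, as compound 1 does.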